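The source may report more compounds than this note shows. Statements on the series, on what has been measured and on what is new or still open speak of the compounds shown alone.

Compound 1 `Cn1ncc(Cl)c1-c1cc(C(=O)N[C@@H]2CN[C@H](CCn3cncn3)C[C@H]2c2ccc(Cl)c(Cl)c2)oc1Cl`: 1560 nM
Compound 2 `Cn1ncc(Cl)c1-c1cc(C(=O)N[C@@H]2CN[C@H](CCN3CCC(O)CC3)C[C@H]2c2ccc(Cl)c(Cl)c2)oc1Cl`: 15900 nM
Compound 3 `C=CC[C@@H]1C[C@@H](c2ccc(Cl)c(Cl)c2)[C@H](NC(=O)c2cc(-c3c(Cl)cnn3C)c(Cl)o2)CN1`: 990 nM

In a functional assay on OVCAR-8 cells (Homo sapiens) for antiproliferative activity (on this read-out lower numbers stand for stronger inhibition and higher numbers for weaker inhibition), compound 3 gives the lowest of the three numbers; one of its gaps is a 1.6-fold lower number from compound 1 to compound 3 (0.20 log units; within the scatter), within the scatter, while the other is a 16-fold lower number from compound 2 to compound 3 (1.21 log units; beyond the scatter), a large step. Compound 4 `Cn1ncc(Cl)c1-c1cc(C(=O)N[C@@H]2CN[C@H](CCN3CCCC3)C[C@H]2c2ccc(Cl)c(Cl)c2)oc1Cl` carries (pyrrolidin-1-yl)methyl in place of vinyl on a saturated chain carbon bound to a saturated ring carbon. Within the data shown here, of the measured steps, the one closest to this change is a 16-fold lower number from compound 2 to compound 3 (1.21 log units; beyond the scatter), read in reverse, whereas a 1.6-fold lower number from compound 1 to compound 3 (0.20 log units; within the scatter) shows that a chain-borne ring at this position need not cost much. The expected step in this assay is therefore a 6.1-fold higher number from compound 3 to compound 4 (0.78 log units; beyond the scatter), a higher number. Compound 4 is estimated at 6000 nM, with a range from 1500 nM to 25000 nM.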

Compound 4, half-maximal inhibitory concentration: 1840 nM
The estimate for compound 4 lay 3.3-fold (0.51 log units) above the measured number; measured number inside the range.
By their numbers in this assay, from the lowest: compounds 3, 1 and 4 (each within the scatter of the next); then compound 2.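

In this assay, the swap of allyl for 2-(pyrrolidin-1-yl)ethyl gives a 1.9-fold higher number from compound 3 to compound 4 (0.27 log units; within the scatter), and the swap of the 1H-1,2,4-triazol-1-yl end group for pyrrolidin-1-yl gives a 1.2-fold higher number from compound 1 to compound 4 (0.07 log units; within the scatter), so this amine-bearing chain stays level with both. The one outlier remains 4-hydroxypiperidin-1-yl, with an 8.6-fold lower number from compound 2 to compound 4 (0.94 log units; beyond the scatter), which shows that a saturated amine ring on this chain does not by itself bring the high number of compound 2. No available evidence explains these differences. Still open, from the compounds shown here alone, is whether the ring size or the hydroxyl of 4-hydroxypiperidin-1-yl accounts for that number; a plain piperidin-1-yl on the same chain would separate the two.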